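This account rests on a few compounds, and the source may have more. Where it says the series, first, only, none or still open, it means among the compounds named here.

Measured in a functional assay on MGC-803 cells (Homo sapiens) for antiproliferative activity, read by MTT assay, with a stated time of 72 h; on this read-out lower numbers stand for stronger inhibition and higher numbers for weaker inhibition:

Compound 1 `CCCSc1nc(N/N=C/c2ccc(Cl)cc2)c2nnn(Cc3ccccc3)c2n1` — > 64000 nM, a limit of the assay rather than a number.
Compound 2 `CCCSc1nc(N/N=C(\C)c2ccccc2O)c2nnn(Cc3ccccc3Cl)c2n1` — 35000 nM.
Compound 3 `C/C(=N\Nc1nc(SCc2ccccc2)nc2c1nnn2Cc1ccccc1)c1ccccc1O` — 850 nM.

Of the two numbers obtained in this assay, compound 2 gives the higher one, and compound 3 gives the lower one, a gap that lies beyond the usual scatter. Compound 1 is the single case that sits at the limit of > 64000 nM in this assay, at which 1 of the 3 values shown sits, so it adds no number to compare. Compound 4 `CCCSc1nc(N/N=C(\C)c2ccccc2O)c2nnn(Cc3cccc(Cl)c3)c2n1` has not yet been measured in this assay. It differs from compound 2 in one place only: 3-chlorophenyl in place of 2-chlorophenyl on a saturated chain carbon bound to an aromatic nitrogen. The two compounds thus share every atom and differ only in where the chlorine sits on the benzyl ring attached to the core. For the measured compounds named here, no measured pair in this set isolates such a move of a chlorine, so there is no step from which its size could be read off. On that basis compound 4 is expected to land near compound 2, with a step from compound 2 to compound 4 of about a 1.2-fold lower number from compound 2 to compound 4 (0.07 log units; within the scatter), which is within the scatter. The estimate for compound 4 in this assay is 30000 nM, with a range from 10000 nM to 90000 nM.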

Compound 4, half-maximal inhibitory concentration: 6500 nM
For compound 4 the middle estimate is 4.6-fold (0.66 log units) above the measured one; measured number below the stated range.
By their numbers in this assay, from the lowest: compound 3; then compound 4; then compound 2. At a limit, above all of these: compound 1.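

In this assay, the place of the chlorine on the benzyl ring turns out to matter: 3-chlorophenyl in place of 2-chlorophenyl on a saturated chain carbon bound to an aromatic nitrogen gives a 5.4-fold lower number from compound 2 to compound 4 (0.73 log units; beyond the scatter). For the compounds shown here, this is the first pair in the set that differs in one place, and it shows a change in the read-out with the same atoms present, joined differently. Nothing given here accounts for this difference.

Still open, on these data alone, is whether 3-bromophenyl or 3-methoxyphenyl at this place would keep the gain seen with 3-chlorophenyl, and how 4-chlorobenzyl would compare with the two chlorobenzyl groups tested. Going by these compounds alone, the set also holds no second pair with this move of the chlorine, so it remains open whether the step carries over to compounds that differ elsewhere.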